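Chloro in Place of Hydrogen on the Benzoyl Ring

The compounds below may be only part of what the source reports. "The series", "measured", "known", "first", "only" and "open" are said of these compounds alone.

Compound 2 `Cc1ccc(OCC(=O)NNC(=O)c2cc3ccccc3oc2=O)c(C(=O)c2ccccc2)c1` gives 86500 nM in a functional assay on Ehrlich cells (Mus musculus) for cytotoxicity, read by trypan blue exclusion, with a stated time of 48 h (a higher number here means a weaker inhibitor, a lower number a stronger inhibitor), the highest number among the two measured compounds. Where compound 2 carries hydrogen, compound 1 `Cc1ccc(OCC(=O)NNC(=O)c2cc3ccccc3oc2=O)c(C(=O)c2ccccc2Br)c1` carries bromo, and in this assay compound 1 gives 9000 nM. Compound 3 `Cc1ccc(OCC(=O)NNC(=O)c2cc3ccccc3oc2=O)c(C(=O)c2ccccc2Cl)c1` differs from compound 2 by chloro in place of hydrogen on an aromatic carbon. For the measured compounds named here, the one step that bears on this change, a 9.6-fold higher number from compound 1 to compound 2 (0.98 log units; beyond the scatter), runs the other way with a halogen of the same kind, so a lower number is expected for compound 3, on the order of a 7.2-fold lower number from compound 2 to compound 3 (0.86 log units; beyond the scatter). Compound 3 is therefore estimated at 12000 nM, within 4000 nM to 40000 nM.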

Compound 3, half-maximal inhibitory concentration: 48400 nM
The estimate for compound 3 lay 4.0-fold (0.61 log units) below the measured number; measured number above the stated range.
By their numbers in this assay, from the lowest: compound 1; then compounds 3 and 2 (each within the scatter of the next).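

Chloro at this place on the ring, ortho to a large group, does not match bromo in this assay: the swap of hydrogen for chloro stays within the scatter (a 1.8-fold lower number from compound 2 to compound 3 (0.25 log units; within the scatter)), while the step between the two halogens lies beyond it (a 5.4-fold higher number from compound 1 to compound 3 (0.73 log units; beyond the scatter)). Among these three compounds, only bromo stands apart from hydrogen, so simply having a halogen here does not bring the change. Nothing available explains the gap between chloro and bromo. Going by these compounds, whether iodo, fluoro, methyl or an amine at this place would track chloro or bromo remains open.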